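This account rests on a few compounds, and the source may have more. Where it says the series, first, only, none or still open, it means among the compounds named here.

Three compounds share one core and differ only in the aromatic group attached to the five-membered aromatic ring with three nitrogens. Compound 1 `Cc1c(O)ccc2c1[C@H](Cn1cc(-c3ccccc3)nn1)[C@@]13CC(=O)[C@@](C)(CC[C@@H]21)C3` carries a phenyl group there. In a functional assay on MCF7 cells (Homo sapiens) for cytotoxicity, read by MTT assay, with a stated time of 4 days (a lower number here means a stronger inhibitor, a higher number a weaker inhibitor), compound 1 gives > 20000 nM, which is a limit of the assay rather than a number. Compound 2 `Cc1c(O)ccc2c1[C@H](Cn1cc(-c3ccc(Cl)cc3)nn1)[C@@]13CC(=O)[C@@](C)(CC[C@@H]21)C3` carries a 4-chlorophenyl group. In this assay compound 2 gives > 20000 nM, again a limit. Compound 3 `Cc1c(O)ccc2c1[C@H](Cn1cc(-c3ccccn3)nn1)[C@@]13CC(=O)[C@@](C)(CC[C@@H]21)C3` carries a pyridin-2-yl group. In this assay compound 3 gives > 20000 nM, also a limit. Because all three values sit at the limit of > 20000 nM in this assay, at which 3 of the 3 values shown sit, none of the steps can be sized: a step that the two limits leave unreadable from compound 1 to compound 2, a step that the two limits leave unreadable from compound 1 to compound 3 and a step that the two limits leave unreadable from compound 2 to compound 3. Compound 3 therefore stands nowhere in particular among the three; it shares the same limit with compound 1 and compound 2.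

Compound 4 `Cc1ccc(-c2cn(C[C@H]3c4c(ccc(O)c4C)[C@@H]4CC[C@@]5(C)C[C@]43CC5=O)nn2)cc1` has not yet been measured. It differs from compound 3 by 4-methylphenyl in place of pyridin-2-yl on an aromatic carbon. Among the measured compounds shown here, no measured step has a readable size, and swapping one aromatic group for another has so far given nothing measurable, so no change beyond the scatter is expected. The step that the limit leaves unreadable from compound 3 to compound 4 is thus expected to be small. The estimate for compound 4 is 30000 nM, between 10000 nM and 100000 nM, most likely again reported only as a limit.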

Compound 4, half-maximal inhibitory concentration: > 20000 nM
Compound 4 ended at the assay's limit; the forecaster's own chance of this, stated with the estimate: 85%; the middle value does not contradict the limit.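

In this assay compound 4 gives > 20000 nM, which is a limit and not a number. Its steps from compound 1, compound 2 and compound 3 cannot be read, since all four compounds share one limit: the limit of > 20000 nM in this assay, at which 4 of the 4 values shown sit. The compounds shown leave open whether any aromatic group on this shared core gives a measurable value in this assay.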